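The source may report more compounds than this note shows. Statements on the series, on what has been measured and on what is new or still open speak of the compounds shown alone.

Working notes on the series, read in a functional assay on A549 cells (Homo sapiens) for antiproliferative activity, read by MTT assay, with a stated time of 72 h; on this read-out lower numbers stand for stronger inhibition and higher numbers for weaker inhibition. Compound 1 `Nc1nc(N)c2cc(CSC(=S)N3CCN(c4ccc(O)cc4)CC3)ccc2n1` gives 4210 nM, compound 2 `Nc1nc(N)c2cc(CSC(=S)N3CCN(c4ccc(F)cc4)CC3)ccc2n1` gives 2040 nM and compound 3 `CC(=O)c1ccc(N2CCN(C(=S)SCc3ccc4nc(N)nc(N)c4c3)CC2)cc1` gives 2550 nM. Compound 3 stands close to both others, with a 1.7-fold lower number from compound 1 to compound 3 (0.22 log units; within the scatter) and a 1.3-fold higher number from compound 2 to compound 3 (0.10 log units; within the scatter) both within the scatter. Only a 2.1-fold lower number from compound 1 to compound 2 (0.31 log units; beyond the scatter) goes beyond the scatter, and modestly.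

Compound 4 `Nc1nc(N)c2cc(CSC(=S)N3CCN(c4ncccn4)CC3)ccc2n1` follows from compound 3 by pyrimidin-2-yl in place of 4-acetylphenyl on an amine nitrogen in a ring. The measured steps bear on this only indirectly. Within the data shown here, they swap a group on an aromatic carbon and keep the ring, and no measured compound has a different ring at this place. Those swaps stayed small, so no step beyond the scatter is expected in this assay, though the uncertainty is wide. The expected change is a 1.2-fold higher number from compound 3 to compound 4 (0.07 log units; within the scatter), which is an estimate. Compound 4 is expected at 3000 nM, with an estimated range of 1200 nM to 7500 nM.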

Compound 4, half-maximal inhibitory concentration: 4010 nM
Compound 4: the middle estimate sits 1.3-fold (0.13 log units) below what was measured; the measured number falls inside the stated range.
By their numbers in this assay, from the lowest: compounds 2, 3, 4 and 1 (each within the scatter of the next, the first and the last beyond it).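

Among these compounds, this is the first change that replaces the whole aromatic ring on the amine nitrogen in a ring, rather than a group on an aromatic carbon. In this assay, all three steps stay within the scatter (a 1.6-fold higher number from compound 3 to compound 4 (0.20 log units; within the scatter); a 2.0-fold higher number from compound 2 to compound 4 (0.29 log units; within the scatter); a 1.0-fold lower number from compound 1 to compound 4 (0.02 log units; within the scatter)), so among these compounds a six-membered aromatic ring of carbon only is not required at this place for a number in this range. No measurement at hand explains this result.

The compounds shown leave open how a non-aromatic group, such as cyclohexyl or a plain methyl, would read on this nitrogen. Also open, going by these compounds, is whether pyridin-2-yl, or a pyrimidin-2-yl ring carrying an amine, would stay within the scatter of compound 4.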